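The source may hold more compounds than are shown below. What is called first, only, known or untested is meant among the compounds shown, and "the series" means these compounds.

Measured so far:
Compound 1 `COc1cc(-c2cc(/C=C/C(=O)c3ccc(N)cc3)[nH]n2)cc(OC)c1OC`: > 100000 nM
Compound 2 `COc1ccc(-c2cc(/C=C/C(=O)c3ccc(N)cc3)[nH]n2)cc1OC`: > 100000 nM
Compound 3 `COc1cc(C(=O)/C=C/c2cc(-c3cc(OC)c(OC)c(OC)c3)n[nH]2)cc(OC)c1OC`: 5860 nM

All three were tested in a functional assay on T47D cells (Homo sapiens) for inhibition, read by sulforhodamine B assay, with a stated time of 48 h; on this read-out lower numbers stand for higher toxicity in this test and higher numbers for lower toxicity in this test. In this assay compound 1 gives only a limit of the test, > 100000 nM. Compound 2 likewise gives only a limit, > 100000 nM. Going by the values given here, compound 3 gives a real number, 5860 nM, the only number among the three. The change from compound 1 to compound 2 is hydrogen in place of methoxy on an aromatic carbon, and the step it made, a step that the two limits leave unreadable from compound 1 to compound 2, cannot be sized, since both values sit at the limit of > 100000 nM in this assay, at which 2 of the 3 values shown sit. The difference between the core of compound 1 and the core of compound 3 is not broken down here.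

Compound 4 `COc1ccc(-c2cc(/C=C/C(=O)c3cc(OC)c(OC)c(OC)c3)[nH]n2)cc1OC` is not yet measured. It arises from compound 3 by the same change, (hydrogen in place of methoxy on an aromatic carbon), at a place described in the same words. Nothing measured tells how large that change is. The step expected is a 2.6-fold higher number from compound 3 to compound 4 (0.41 log units; beyond the scatter). That rests on the unreadable step that the two limits leave unreadable from compound 1 to compound 2 and on compound 3 at 5860 nM. Compound 4 is therefore estimated at 15000 nM in this assay, with a range from 4000 nM to 70000 nM.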

Compound 4, concentration lethal to 50% of the cells: > 100000 nM
Compound 4: a limit, no number; the forecaster's own chance of this, stated with the estimate: 25%; middle value at least 6.6-fold (0.82 log units) away from the limit.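

In this assay, hydrogen in place of methoxy on the core of compound 3 gives an at least 17-fold higher number from compound 3 to compound 4 (1.23 log units; beyond the scatter), so in the one case that can be read, the change goes with a large move towards lower toxicity, and its true size could be larger still. Compound 4 gives > 100000 nM, which is a limit and not a number. The same change on the core of compound 1 cannot be read, so this does not show that the step carries from one core to the other, only that compound 2 stays at the same limit as compound 1: the limit of > 100000 nM in this assay, at which 3 of the 4 values shown sit.

On these data alone, whether a hydroxyl group or an ethoxy group in place of that methoxy on compound 3 would keep a readable value remains open. So does whether any compound on the core of compound 1 can give a real number in this assay.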